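A few compounds are considered here, and "the series" means these few. Any claim that something is new, unique, unknown or untested is made for them only; others in the source may bear on it.

Cytotoxicity in this series is read as an ADME assay on HEL cells (Homo sapiens) for cytotoxicity, with a stated time of 3 days (on this read-out higher numbers stand for lower toxicity in this test and lower numbers for higher toxicity in this test), on four compounds built on one shared core: compound 1 `C=Cc1ccc(-c2cc(C)c3ncc(CSCc4ccccc4)n3c2)cc1`, compound 2 `Cc1cc(-c2ccsc2)cn2c(CSCc3ccccc3)cnc12`, compound 3 `Cc1cc(N2CCN(C)CC2)cn2c(CSCCc3ccccc3)cnc12` and the unmeasured compound 4 `Cc1cc(Sc2ccc(Cl)cc2)cn2c(CSCCc3ccccc3)cnc12`.

Compound 1 gives only a limit, >= 100 ug/mL, in this assay. Compound 2 gives 4 ug/mL and compound 3 gives 20 ug/mL. Among the measured compounds shown here, the single measured step, an at least 25-fold lower number from compound 1 to compound 2 (1.39 log units; beyond the scatter), is large and runs towards higher toxicity, and it is bounded on one side by the limit of >= 100 ug/mL in this assay, at which 1 of the 3 values shown sits. Among the two plain numbers compound 3 stands highest, with compound 2 the nearer and lower one, a gap beyond the scatter.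

The step to compound 4 is (4-chlorophenyl)sulfanyl in place of 4-methylpiperazin-1-yl on an aromatic carbon. For the measured compounds named here, no measured pair carries this exchange. The step from compound 1 to compound 2 touches the same aromatic carbon and shows that changes there can move this assay a long way; in it the aromatic substituent of compound 2 sits at the lower number. Since the entering group also carries an aromatic ring, a move towards lower numbers is expected, of moderate size, though the direction is not secured by a matched pair.

Compound 4 is therefore estimated at 8 ug/mL, within 2 ug/mL to 40 ug/mL. That estimate amounts to an expected step of a 2.5-fold lower number from compound 3 to compound 4 (0.40 log units; beyond the scatter).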

Compound 4, minimum cytotoxic concentration: 20 ug/mL
Compound 4: the middle estimate sits 2.5-fold (0.40 log units) below what was measured; low and high end bracket the measured number.
By their numbers in this assay, from the lowest: compound 2; then compounds 3 and 4 (each within the scatter of the next). At a limit, above all of these: compound 1.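

In this assay, no change at the digits printed from compound 3 to compound 4 (within the scatter), so on this aromatic carbon a (4-chlorophenyl)sulfanyl group and a 4-methylpiperazin-1-yl group cannot be told apart in this test, and an entering aromatic ring linked through sulfur does not by itself bring a lower number in this pair. Among the compounds shown here, until now the only exchange read at this carbon was large, an at least 25-fold lower number from compound 1 to compound 2 (1.39 log units; beyond the scatter), and the new pair shows that the position does not respond to every exchange, so a large step here belongs to that pair and not to the position as a whole. The size of that large step remains open on one side: the limit of >= 100 ug/mL in this assay, at which 1 of the 4 values shown sits.

Going by these compounds, the two steps at this carbon stand on different backgrounds, as the chain on the shared core is not the same in the two pairs, so it remains open whether the thiophen-3-yl group would give the same low number with the chain of compound 3. On these data alone, it is also open whether a primary amine, a carboxylic acid or a 4-chlorophenyl group joined directly to this carbon, without the sulfur, would keep the number of compound 3 or shift it.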